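The compounds below may be only part of what the source reports. "The series", "measured", "known", "first", "only" and "open" are said of these compounds alone.

Compound 2, `CCCCc1ccc(CNC(C)=O)c(=O)n1Cc1ccc(-c2ccccc2-c2nn[nH]n2)cc1`, is the acetamido member of a pair of closely related compounds that share one core. In a functional assay (aorta) for antagonist activity, with Oryctolagus cuniculus as the target (on this read-out higher numbers stand for weaker inhibition and lower numbers for stronger inhibition), compound 2 gives 3 nM, which is the lowest of the two numbers recorded. Its nearest neighbour is compound 1, `CCCCc1ccc(CNC(=O)NC2CCCCC2)c(=O)n1Cc1ccc(-c2ccccc2-c2nn[nH]n2)cc1`, which in this assay gives 90 nM. For the measured compounds named here, the one step available between measured compounds, a 30-fold lower number from compound 1 to compound 2 (1.48 log units; beyond the scatter), was obtained by putting methyl in place of cyclohexylamino on the carbonyl carbon.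

Compound 3, `CCCCc1ccc(CN(Cc2ccccc2)C(C)=O)c(=O)n1Cc1ccc(-c2ccccc2-c2nn[nH]n2)cc1`, differs from compound 2 in another place: benzyl in place of hydrogen on an amide-type nitrogen. Going by the values given here, no measured step touches this nitrogen, so the available pair bears on the change only loosely; what it shows is that a small group at the amide end gave the low number of compound 2, while a larger assembly there gave the higher number of compound 1. A benzyl group on the nitrogen is again an enlargement of that end, and the expected result for compound 3 in this assay is a moderate rise, a 5.0-fold higher number from compound 2 to compound 3 (0.70 log units; beyond the scatter). Compound 3 is therefore estimated at 15 nM, with a range from 3 nM to 100 nM.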

Compound 3, half-maximal inhibitory concentration: 1 nM
Estimate against measurement, compound 3: 15-fold (1.18 log units) above; measured number below the stated range.
By their numbers in this assay, from the lowest: compound 3; then compound 2; then compound 1.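

In this assay the amide-type nitrogen accepts benzyl in place of the amide hydrogen with no loss, and the number even falls: a 3.0-fold lower number from compound 2 to compound 3 (0.48 log units; beyond the scatter). The earlier pair had shown only a change on the carbonyl carbon, where cyclohexylamino gave a higher number than methyl, so added bulk at this end of the molecule does not raise the number in every place; the hydrogen on this nitrogen is also not required for a low number. Compound 3 now stands lowest of the three, and the full exchange of acetyl(benzyl)amino for (cyclohexylcarbamoyl)amino spans a 90-fold lower number from compound 1 to compound 3 (1.95 log units; beyond the scatter), although no measurement shown here accounts for the gain from benzyl.

Going by these compounds, it remains open whether this gain belongs to benzyl itself or would also appear with a simple methyl, a longer chain such as phenethyl, or a pyridylmethyl group on the same nitrogen. Also open, on these data alone, is whether a carboxylic acid or an amine carried on the benzyl ring would keep the number this low.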